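Aryl ether variation in the pyrrolidine acetic acid series

The source may report more compounds than this note shows. Statements on the series, on what has been measured and on what is new or still open speak of the compounds shown alone.

Measured so far:
- compound 1 `Cc1ccccc1Cc1ccc(N2CC[C@H](C)[C@H]2CC(=O)O)cc1`: 120 nM
- compound 2 `O=C(O)C[C@@H]1C[C@H](C(F)(F)F)CN1c1ccc(Oc2ccccc2C(F)(F)F)cc1`: 310 nM
- compound 3 `O=C(O)C[C@@H]1C[C@H](C(F)(F)F)CN1c1ccc(Oc2ccccc2OC(F)(F)F)cc1`: 170 nM

In a functional assay on cells for agonist activity at Free fatty acid receptor 1 (Homo sapiens), read by FLIPR and calcium flux, with a stated time of 100 s (a lower number here means that less compound is needed, a higher number that more compound is needed for the effect), compound 2 gives 310 nM, the highest of the three numbers. Its nearest neighbour is compound 3, which in this assay gives 170 nM; the step of a 1.8-fold lower number from compound 2 to compound 3 (0.26 log units; within the scatter) stays within the scatter. Among the measured compounds shown here, compound 1, a different core substitution pattern and linker, gives 120 nM in this assay, a gap beyond the scatter, but no single-point step connects it to compound 2.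

Compound 4 `Cc1c(Cl)cccc1Oc1ccc(N2C[C@@H](C(F)(F)F)C[C@H]2CC(=O)O)cc1` has not yet been measured. It differs from compound 2 by 3-chloro-2-methylphenyl in place of 2-(trifluoromethyl)phenyl on an oxygen on an aromatic ring. For the measured compounds named here, only the step from compound 2 to compound 3 touches the same aryl ring, and it was within the scatter; no measured step covers a chlorine or methyl substituent at this ring. Compound 4 is therefore expected to land close to compound 2 in this assay, with a step of a 1.4-fold lower number from compound 2 to compound 4 (0.15 log units; within the scatter) that may not exceed the scatter, leaning slightly toward a lower number. The estimate for compound 4 in this assay is 220 nM, with a range from 70 nM to 700 nM.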

Compound 4, half-maximal effective concentration: 82 nM
For compound 4 the middle estimate is 2.7-fold (0.43 log units) above the measured one; the range from low to high includes it.
By their numbers in this assay, from the lowest: compounds 4, 1, 3 and 2 (each within the scatter of the next, the first and the last beyond it).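

In this assay, the aryl group on the ether oxygen can move the number beyond the scatter: a 3.8-fold lower number from compound 2 to compound 4 (0.58 log units; beyond the scatter) comes with 3-chloro-2-methylphenyl in place of 2-(trifluoromethyl)phenyl, whereas the earlier change on this ring, a 1.8-fold lower number from compound 2 to compound 3 (0.26 log units; within the scatter), stayed within it. The lower number comes with a group of fewer heavy atoms than the one it replaces, so at this position a larger group is not required for a lower number. Nothing measured here accounts for the step.

Chlorine and methyl enter together and the trifluoromethyl leaves in the same change, so the contribution of each remains unresolved; 3-chlorophenyl and 2-methylphenyl on this oxygen would separate them. Also open, going by these compounds, are how a nitrile or an amine on this ring would read in this assay, and whether 3-chloro-2-methylphenyl gives a similar step on the core of compound 1.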